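Exchanging one aromatic group on compound 1

The source may hold more compounds than are shown below. What is called first, only, known or untested is meant among the compounds shown, and "the series" means these compounds.

Going by the values given here, in a functional assay on Bel-7402 cells (Homo sapiens) for inhibition, read by MTT assay, with a stated time of 72 h (on this read-out higher numbers stand for weaker inhibition and lower numbers for stronger inhibition), compound 1 `CNC(=O)CCCCCCCn1nc(-c2cnc3[nH]ccc3c2)c2c(N)ncnc21` gives 17400 nM, the higher of the two numbers so far. Among the compounds with values here, compound 2 `Nc1nc2cc(-c3nn(CCCCC(=O)NO)c4ncnc(N)c34)ccc2o1` gives 2400 nM in this assay, but it differs from compound 1 in more than one place, so no measured step isolates a single change. Compound 3 `CNC(=O)CCCCCCCn1nc(-c2ccc3oc(N)nc3c2)c2c(N)ncnc21` differs from compound 1 by one exchange: a group of 10 heavy atoms (7 carbon, 2 nitrogen, 1 oxygen; one five-membered aromatic ring with 2 hetero atoms, one six-membered aromatic ring of carbon only) in place of a group of 9 heavy atoms (7 carbon, 2 nitrogen; one five-membered aromatic ring with 1 hetero atom, one six-membered aromatic ring with 1 hetero atom), on an aromatic carbon. Compound 2 carries the same 2-amino-1,3-benzoxazol-5-yl group, so a modest fall in the number is expected. The estimated change is a 2.2-fold lower number from compound 1 to compound 3 (0.34 log units; beyond the scatter), towards stronger inhibition. For compound 3 the expected value is 8000 nM, with an estimated range of 2500 nM to 25000 nM.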

Compound 3, half-maximal inhibitory concentration: 13200 nM
The estimate for compound 3 lay 1.7-fold (0.22 log units) below the measured number, and the stated range covers the measured number.
By their numbers in this assay, from the lowest: compound 2; then compounds 3 and 1 (each within the scatter of the next).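

In this assay, placing 2-amino-1,3-benzoxazol-5-yl on this aromatic carbon moves the number only within the scatter, with a 1.3-fold lower number from compound 1 to compound 3 (0.12 log units; within the scatter), so the exchange at this position does not separate the two groups. The chain end does separate compounds: 3-(methylcarbamoyl)propyl in place of hydroxycarbamoyl gives a 5.5-fold higher number from compound 2 to compound 3 (0.74 log units; beyond the scatter), beyond the scatter. Nothing available explains either step. Still open, as far as these compounds go, is how a carboxylic acid at the chain end would read in this assay. Also open, from the compounds shown here alone, is whether hydroxycarbamoyl on a longer chain keeps the lower number.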